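The source may report more compounds than this note shows. Statements on the series, on what has been measured and on what is new or still open speak of the compounds shown alone.

Compound 1 `O=C(/C=C/c1ccccc1)c1ccc(N2CCN(c3ccc(Cl)c(Cl)c3)CC2)cc1` in a functional assay on the whole organism (strain Kunming) for inhibition, with Mus musculus as the target, with a stated time of 1 h, at a dose of 40 mg/kg by the oral route; a higher number here means more inhibition at the dose given (going by the name of the read-out), a lower number less inhibition: 13.4%
Compound 2 `O=C(/C=C/c1ccccc1)c1ccc(N2CCN(c3cccc(Cl)c3Cl)CC2)cc1` in this assay: 30.7%

Among the measured compounds shown here, compound 2 stands highest of the two measured numbers, its nearest neighbour being compound 1, and the one measured step, a number 17.3 percentage points higher from compound 1 to compound 2 (beyond the scatter), lies beyond the scatter. Compound 3 `O=C(/C=C/c1ccccc1)c1ccc(N2CCN(c3cccc(C(F)(F)F)c3)CC2)cc1` differs from compound 2 by 3-(trifluoromethyl)phenyl in place of 2,3-dichlorophenyl on an amine nitrogen in a ring. For the measured compounds named here, no measured step concerns a trifluoromethyl group, so the only step, a number 17.3 percentage points higher from compound 1 to compound 2 (beyond the scatter), gives just a loose sense of how much a change on this ring can move the read-out. Compound 3 is therefore expected to fall between the two measured values, with a step of a number 8.7 percentage points lower from compound 2 to compound 3 (within the scatter). The estimate for compound 3 is 22%, from 8% to 38%.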

Compound 3, a percentage reported as inhibition, in the whole organism at one dose (the size of the read-out at that dose, not a potency): 25%
For compound 3 the middle estimate is 3 percentage points below the measured one; the measured number falls inside the stated range.
By their numbers in this assay, from the lowest: compound 1; then compounds 3 and 2 (each within the scatter of the next).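

In this assay, the step to 3-(trifluoromethyl)phenyl from 2,3-dichlorophenyl leaves the two compounds within the scatter (a number 5.7 percentage points lower from compound 2 to compound 3 (within the scatter)), while the step from 3,4-dichlorophenyl clears it (a number 11.6 percentage points higher from compound 1 to compound 3 (beyond the scatter)). This position therefore accepts a group without chlorine and still stays clear of the number of compound 1. Nothing measured here accounts for these differences.

The compounds shown leave open how a methoxy group or a nitrile on this phenyl ring would compare, and whether an unsubstituted phenyl would stand with compound 1 or with compound 2.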